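Swapping fluoro for methoxy on the indole of compound 2

The source may report more compounds than this note shows. Statements on the series, on what has been measured and on what is new or still open speak of the compounds shown alone.

Compound 1 `O=C(CN1CCN(C(=O)c2ccc(Br)cc2)CC1)N1CCN(CCCc2c[nH]c3ccc(F)cc23)CC1` and compound 2 `O=C(CN1CCN(C(=O)c2cccc(Br)c2)CC1)N1CCN(CCCc2c[nH]c3ccc(F)cc23)CC1` share a core and differ only in the bromophenyl on the carbonyl carbon. In an ADME assay on SH-SY5Y cells (Homo sapiens) for cytotoxicity, read by MTT assay, with a stated time of 72 h (on this read-out higher numbers stand for weaker inhibition and lower numbers for stronger inhibition), compound 1 gives 47400 nM, and compound 2 gives 71600 nM. The step of a 1.5-fold higher number from compound 1 to compound 2 (0.18 log units; within the scatter) does not reach beyond the scatter, so compound 2 stands at the highest of the two numbers without being separable from compound 1. Compound 3 `COc1ccc2[nH]cc(CCCN3CCN(C(=O)CN4CCN(C(=O)c5cccc(Br)c5)CC4)CC3)c2c1` keeps the 3-bromophenyl of compound 2 and changes the other end: methoxy in place of fluoro on an aromatic carbon. Among the compounds with values here, no measured step touches this position, so the only guide is that both measured compounds sit at weak inhibition in this assay and that the one measured step is small. Compound 3 is therefore expected to show no step beyond the scatter, a 1.0-fold lower number from compound 2 to compound 3 (0.01 log units; within the scatter), with an estimate of 70000 nM and a range from 30000 nM to 160000 nM.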

Compound 3, half-maximal inhibitory concentration: 105000 nM
Compound 3: middle estimate off by 1.5-fold (0.18 log units), on the low side; measured number inside the range.
By their numbers in this assay, from the lowest: compounds 1, 2 and 3 (each within the scatter of the next, the first and the last beyond it).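

In this assay, within the data shown here, the one change at the indole end of the molecule, from 5-fluoro-1H-indol-3-yl to 5-methoxy-1H-indol-3-yl, gives a 1.5-fold higher number from compound 2 to compound 3 (0.17 log units; within the scatter) and so does not separate the two compounds. Among these compounds, the earlier step touched only the bromophenyl, so this is the first reading at this position: here, replacing fluoro with methoxy, which has one more heavy atom and a hydrogen-bond acceptor, leaves the result within the scatter. No available evidence bears on this result.

As far as these compounds go, it remains open whether methoxy would read the same alongside the 4-bromophenyl of compound 1. From the compounds shown here alone, it is also open whether an amine or a carboxylic acid at this position would produce a step beyond the scatter.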